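The compounds below may be only part of what the source reports. "The series", "measured", "known", "first", "only" and "open" are said of these compounds alone.

Compound 1 `Cc1ccc(-c2csc(NC(=O)COc3ccccc3)n2)cc1` is the weaker of the two compounds measured in a functional assay on MDA-MB-468 cells (Homo sapiens) for cytotoxicity, read by trypan blue exclusion, with a stated time of 48 h; a lower number here means a stronger inhibitor, a higher number a weaker inhibitor: compound 1 gives 54500 nM, the highest of the two numbers. Compound 2 `Cc1ccc(-c2csc(NC(=O)COc3ccc(F)cc3F)n2)cc1` gives 10200 nM in this assay, a step of a 5.3-fold lower number from compound 1 to compound 2 (0.73 log units; beyond the scatter). Compound 3 `O=C(COc1ccccc1)Nc1nc(-c2ccc(Br)cc2)cs1` differs from compound 1 in another place: bromo in place of methyl on an aromatic carbon. Among the compounds with values here, no measured step changes this part of the structure, so nothing here shows how this position responds. Compound 3 is therefore expected to stay near compound 1, a step of a 1.2-fold lower number from compound 1 to compound 3 (0.08 log units; within the scatter) within the scatter, with an estimate of 45000 nM ranging from 15000 nM to 140000 nM.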

Compound 3, half-maximal inhibitory concentration: 37100 nM
Estimate against measurement, compound 3: 1.2-fold (0.08 log units) above; the measured number falls inside the stated range.
By their numbers in this assay, from the lowest: compound 2; then compounds 3 and 1 (each within the scatter of the next).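

In this assay, the exchange of 4-methylphenyl for 4-bromophenyl gives a 1.5-fold lower number from compound 1 to compound 3 (0.17 log units; within the scatter) and so leaves the two compounds indistinguishable. Within the data shown here, on this aromatic carbon, para to a large group, bromo and methyl therefore cannot be told apart in this assay, a first reading for a position that no earlier step touched. No available evidence explains this match.

Going by these compounds, whether an amine or a carboxylic acid at this position would shift the number remains open. So does whether 4-bromophenyl and the 2,4-difluorophenyl group together would behave differently from either change alone.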